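Lengthening the ethyl chain on the ring nitrogen

This account rests on a few compounds, and the source may have more. Where it says the series, first, only, none or still open, it means among the compounds named here.

Among the compounds with values here, compound 1 `CCN1CCN(c2ccc(S(=O)(=O)Oc3cccc(F)c3)cc2)C1=O` is the weakest inhibitor of the three compounds measured so far in a functional assay on M21 cells (Homo sapiens) for antiproliferative activity, read by sulforhodamine B assay, with a stated time of 48 h; a higher number here means a weaker inhibitor, a lower number a stronger inhibitor: compound 1 gives 11000 nM. Its nearest neighbour is compound 2 `CCN1CCN(c2ccc(S(=O)(=O)Oc3cccc(Cl)c3)cc2)C1=O`, which gives 3900 nM, a step that is a 2.8-fold lower number from compound 1 to compound 2 (0.45 log units; beyond the scatter). Furthest away is compound 3 `CCN1CCN(c2ccc(S(=O)(=O)Oc3cccc(I)c3)cc2)C1=O`, which gives 2200 nM, so that a 5.0-fold lower number from compound 1 to compound 3 (0.70 log units; beyond the scatter). Between the two stronger compounds the gap is small: a 1.8-fold lower number from compound 2 to compound 3 (0.25 log units; within the scatter).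

Compound 4 `CCCN1CCN(c2ccc(S(=O)(=O)Oc3cccc(F)c3)cc2)C1=O` differs from compound 1 in another way: methyl in place of hydrogen on a saturated chain carbon, two bonds along the chain from an amide-type nitrogen in a ring. Read one bond further out, the ethyl on the ring nitrogen becomes propyl.

All three measured steps swap one halogen for another on an aromatic carbon; none of them changes the chain on the amide-type nitrogen in the ring. Within the data shown here, they therefore say nothing direct about the step from compound 1 to compound 4, and there is no other compound with a longer chain to compare. Without such evidence, the step is expected to be small, in either direction, and most likely within the scatter: a 1.1-fold lower number from compound 1 to compound 4 (0.04 log units; within the scatter). Compound 4 is estimated at 10000 nM in this assay, with a range from 4000 nM to 25000 nM.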

Compound 4, half-maximal inhibitory concentration: 12000 nM
The estimate for compound 4 lay 1.2-fold (0.08 log units) below the measured number, and the stated range covers the measured number.
By their numbers in this assay, from the lowest: compounds 3 and 2 (each within the scatter of the next); then compounds 1 and 4 (each within the scatter of the next).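

Putting methyl in place of hydrogen on a saturated chain carbon, two bonds along the chain from the amide-type nitrogen in the ring, turns ethyl into propyl and gives a 1.1-fold higher number from compound 1 to compound 4 (0.04 log units; within the scatter) in this assay, so the two compounds cannot be told apart in this assay. Within the data shown here, this is the first reading at this chain, and it stands in contrast to the halogen swap on the aromatic carbon, where a 5.0-fold lower number from compound 1 to compound 3 (0.70 log units; beyond the scatter) lay beyond the scatter. No measurement at hand bears on this result, so it remains a bare observation about activity in these cells.

As far as these compounds go, a single step with one added carbon shows no trend in chain length, so a methyl on the ring nitrogen, a longer chain such as butyl or hexyl, a branched chain such as isopropyl, and a chain ending in an amine or a carboxylic acid all remain open. From the compounds shown here alone, it also remains open whether propyl would read the same alongside the chloro or iodo group on the aromatic carbon.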